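Aryl exchange on a chalcone amide: Vero cell tolerance

The compounds below may be only part of what the source reports. "The series", "measured", "known", "first", "only" and "open" are said of these compounds alone.

Compound 1 `COC(=O)c1cc(-c2cccc(NC(=O)c3ccc(/C=C/C(=O)c4cccs4)cc3)c2)on1` — "not determined" (no result reported)
Compound 2 `COC(=O)c1cc(-c2cccc(NC(=O)c3ccc(/C=C/C(=O)c4ccc(C)c(F)c4)cc3)c2)on1` — > 50 ug/mL

Two compounds have been examined in an ADME assay on Vero cells (Chlorocebus sabaeus) for cytotoxicity, read by MTT assay, with a stated time of 72 h; a higher number here means that more compound is tolerated, a lower number that less compound is tolerated. For compound 1 the result in this assay is "not determined" (no result reported). In this assay compound 2 reaches > 50 ug/mL, which is a limit of the assay and not a measured number; it is the limit of > 50 ug/mL in this assay, at which 1 of the 2 values shown sits. Going by the values given here, no step between two measured compounds can therefore be drawn, and the only fixed point is that compound 2 sits at the limit.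

Compound 3 `COC(=O)c1cc(-c2cccc(NC(=O)c3ccc(/C=C/C(=O)c4ccc(OC)c([N+](=O)[O-])c4)cc3)c2)on1` has not yet been tested. It differs from compound 2 in a single place: 4-methoxy-3-nitrophenyl in place of 3-fluoro-4-methylphenyl on a carbonyl carbon. Among the compounds with values here, nothing among the measured compounds tells how this exchange affects tolerance, so the step from compound 2 to compound 3 is expected to be none beyond the scatter, a number no higher from compound 2 to compound 3 (the limit leaves the size open). Compound 3 is accordingly estimated to give 50 ug/mL in this assay, within a range from 20 ug/mL to 100 ug/mL, with a fair chance that only a limit is reported again.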

Compound 3, half-maximal cytotoxic concentration: > 40 ug/mL
Compound 3 gave a limit, no number (the forecaster's own chance of this, stated with the estimate: 60%); the middle value does not contradict the limit.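

Compound 3 gives > 40 ug/mL, which is a limit of the assay and not a number. Compound 2 also stands at a limit, > 50 ug/mL. Going by these compounds alone, no step between compound 2 and compound 3 can therefore be read. The compounds shown leave open whether 4-methoxy-3-nitrophenyl in place of 3-fluoro-4-methylphenyl changes tolerance in this assay at all.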